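This account rests on a few compounds, and the source may have more. Where it says the series, first, only, none or still open, it means among the compounds named here.

Measured compounds: compound 1 `C#CCNC1CCc2c(SCCc3cccc(Cl)c3)cccc21`, "not determined" (no result reported); compound 2 `C#CCNC1CCc2c(SCc3ccccc3)cccc21`, "not active" (no number reported); compound 3 `C#CCNC1CCc2c(OCc3cccc(C(F)(F)F)c3)cccc21`, 5410 nM.

In an ADME assay on isolated protein for inhibition of Amine oxidase [flavin-containing] B (Homo sapiens) (a lower number here means a stronger inhibitor, a higher number a weaker inhibitor), compound 1 gives "not determined" (no result reported), so no single number stands for it, and compound 2 likewise returns "not active" (no number reported) with no number. Only compound 3 carries a figure, at 5410 nM in this assay. Compound 4 `C#CCNC1CCc2c(SCCc3ccc(Cl)c(Cl)c3)cccc21` is not yet measured. It differs from compound 1 by chloro in place of hydrogen on an aromatic carbon, a change that turns 3-chlorophenyl into 3,4-dichlorophenyl. For the measured compounds named here, with no number for compound 1 and no step between measured compounds, no size or direction can be given for the move to compound 4 in this assay; the figure for compound 3 is the only anchor. Compound 4 is expected to come out near 3000 nM, within a range from 400 nM to 30000 nM, with a fair chance that no number is returned at all.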

Compound 4, half-maximal inhibitory concentration: 2820 nM
Compound 4: the middle estimate sits 1.1-fold (0.03 log units) above what was measured; the range from low to high includes it.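

No step can be read between compound 1 and compound 4: in this assay compound 1 has no single number. No supporting data bear on this result. The compounds shown leave open what the added chloro does to inhibition.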